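Removing a methyl from the quinoline ether of a diterpenoid lactone

A few compounds are considered here, and "the series" means these few. Any claim that something is new, unique, unknown or untested is made for them only; others in the source may bear on it.

Measured compounds:
- compound 1, `C=C1CC[C@H]2[C@@](C)(CCC(=O)[C@@]2(C)COC(C)=O)[C@@H]1C/C=C1/C(=O)OC[C@@H]1Oc1c(Cl)cc(Cl)c2cccnc12`: 57400 nM
- compound 2, `C=C1CC[C@@H]2[C@](C)(CO)[C@H](O)CC[C@@]2(C)[C@@H]1C/C=C1/C(=O)OC[C@@H]1Oc1cccc2ccc(C)nc12`: 99800 nM

Of the compounds shown here, two have been measured in a toxicity assay on Vero cells (Chlorocebus sabaeus) for cytotoxicity, with a stated time of 48 h; a lower number here means that less compound is tolerated, a higher number that more compound is tolerated. Compound 1, with the structure `C=C1CC[C@H]2[C@@](C)(CCC(=O)[C@@]2(C)COC(C)=O)[C@@H]1C/C=C1/C(=O)OC[C@@H]1Oc1c(Cl)cc(Cl)c2cccnc12`, gives 57400 nM in this assay. Compound 2, with the structure `C=C1CC[C@@H]2[C@](C)(CO)[C@H](O)CC[C@@]2(C)[C@@H]1C/C=C1/C(=O)OC[C@@H]1Oc1cccc2ccc(C)nc12`, gives 99800 nM in this assay. The two numbers lie within the usual scatter of each other, so compound 2 cannot be set apart from compound 1 on the basis of these values; both are tolerated at high concentration. For the measured compounds named here, the two compounds differ in several places at once, so no single step between them can be read.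

Compound 3, `C=C1CC[C@@H]2[C@](C)(CO)[C@H](O)CC[C@@]2(C)[C@@H]1C/C=C1/C(=O)OC[C@@H]1Oc1cccc2cccnc12`, has not been measured. It differs from compound 2 in one place: hydrogen in place of methyl on an aromatic carbon. The rest of the shared core and the lactone ether are unchanged. With hydrogen in place of methyl on an aromatic carbon, and nothing in the measured pair pointing to a large effect of such a small change, no step beyond the scatter is expected in this assay. The step from compound 2 to compound 3 is estimated as a 1.1-fold lower number from compound 2 to compound 3 (0.04 log units; within the scatter), essentially flat. Compound 3 is therefore expected to give about 90000 nM in this assay, within a range of 40000 nM to 200000 nM.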

Compound 3, half-maximal cytotoxic concentration: 20800 nM
Compound 3: the middle estimate sits 4.3-fold (0.64 log units) above what was measured; the measured number lies below the stated range.
By their numbers in this assay, from the lowest: compound 3; then compounds 1 and 2 (each within the scatter of the next).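

Going from the (2-methylquinolin-8-yl)oxy group to the (quinolin-8-yl)oxy group, with everything else in the structure unchanged, gives a 4.8-fold lower number from compound 2 to compound 3 (0.68 log units; beyond the scatter) in this assay. For the compounds shown here, this is the first step that can be read, since the earlier pair differs in several places at once, and it shows that this one methyl, on the aromatic carbon next to the ring nitrogen, is enough to move the number beyond the scatter: less compound is tolerated once the methyl gives way to hydrogen. Nothing measured here accounts for the size or the direction of this step.

As far as these compounds go, it remains open whether an ethyl, a methoxy or an amine on that same carbon would keep the number close to that of compound 2 or leave it close to that of compound 3. Also open, from the compounds shown here alone, is whether exchanging methyl for hydrogen at this place would give a step of similar size on the core of compound 1, or with chlorine elsewhere on the quinoline ether.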